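The compounds below may be only part of what the source reports. "The series", "measured", "known", "first", "only" and "open" are said of these compounds alone.

Compound 1 `O=C(CCc1cccc2c1B(O)OC2)Nc1ccc(Br)cc1` gives 46000 nM
Compound 2 `CC(C)(C)c1ccc(NC(=O)CCc2cccc3c2B(O)OC3)cc1` gives 19000 nM

Both values come from a functional assay on HCT-116 cells (Homo sapiens) for antiproliferative activity, read by MTT assay, with a stated time of 72 h; on this read-out higher numbers stand for weaker inhibition and lower numbers for stronger inhibition. Of the two compounds measured there, compound 2 has the lower number, 19000 nM, and so shows the stronger inhibition. The next compound, compound 3 `O=C(CCc1cccc2c1B(O)OC2)Nc1ccc([N+](=O)[O-])cc1`, has not yet been measured. It keeps the shared core and changes one group of compound 2: nitro in place of tert-butyl on an aromatic carbon. In words, nitro takes the place of tert-butyl on an aromatic carbon.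

Among the compounds with values here, only one measured step bears on this change: a 2.4-fold lower number from compound 1 to compound 2 (0.38 log units; beyond the scatter). That step is modest, and it swaps bromo for tert-butyl. Within the data shown here, no measured compound carries a nitro group, so the evidence is thin. Compound 3 gives up the tert-butyl group that accompanied the lower number, so a modest move back toward the value of compound 1 seems the most reasonable expectation in this assay, meaning somewhat weaker inhibition. The expected change is a 1.6-fold higher number from compound 2 to compound 3 (0.20 log units; within the scatter). For compound 3 the estimated value is 30000 nM, with an expected range from 10000 nM to 90000 nM.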

Compound 3, half-maximal inhibitory concentration: > 100000 nM
Compound 3 gave a limit, no number (the forecaster's own chance of this, stated with the estimate: 10%); middle value at least 3.3-fold (0.52 log units) away from the limit.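

In this assay compound 3 gives > 100000 nM, which is a limit of the assay and not a number: the limit of > 100000 nM in this assay, at which 1 of the 3 values shown sits. Placing nitro in place of tert-butyl on this aromatic carbon, para to a large group, brings an at least 5.2-fold higher number from compound 2 to compound 3 (0.72 log units; beyond the scatter), while nitro in place of bromo brings an at least 2.1-fold higher number from compound 1 to compound 3 (0.33 log units; beyond the scatter). The earlier pair showed only a modest shift at this position, whereas nitro shows that the group here can push the read-out further, and compound 3 now gives the weakest inhibition of the three, with every step between them beyond the scatter.

As far as these compounds go, how far the true value of compound 3 lies past the limit stays open, so the full size of both steps is unknown. Three groups are also too few to tell which feature of a group sets the result at this carbon, and an amine or a carboxylic acid in the same place could help to separate what nitro, bromo and tert-butyl each contribute.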